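Swapping a Thiophene for a Pyridine on a Shared Core

This account rests on a few compounds, and the source may have more. Where it says the series, first, only, none or still open, it means among the compounds named here.

Three compounds share one core and differ only in the aromatic groups attached to it. Compound 1 `Oc1cccc(-c2cc(-c3cccnc3)nc(-c3cccc(Cl)c3)c2)c1` was included in the study, but in a functional assay on T47D cells (Homo sapiens) for cytotoxicity, read by CCK-8 assay and cell counting, with a stated time of 2 days (a higher number here means a weaker inhibitor, a lower number a stronger inhibitor), compound 1 gives "not determined" (no result reported), so it offers no number to work with.

For the measured compounds named here, compound 2 `Oc1ccc(-c2cc(-c3cccc(Cl)c3)nc(-c3cccs3)c2)cc1` is the only compound with a measured value. In this assay compound 2 gives 5350 nM. Going by the values given here, compound 2 therefore stands alone: there is nothing to compare it with, and no step between measured compounds can be drawn.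

Compound 3 `Oc1ccc(-c2cc(-c3cccnc3)nc(-c3cccc(Cl)c3)c2)cc1` has not yet been measured. It differs from compound 2 in one place: pyridin-3-yl in place of thiophen-2-yl on an aromatic carbon. Both the group that leaves and the group that enters are small aromatic rings with a single hetero atom and a single hydrogen-bond acceptor, and the rest of the molecule is unchanged.

Among the compounds with values here, with no measured step of this kind to lean on, the change is expected to move the half-maximal inhibitory concentration little, if at all, beyond the usual scatter, and in no clear direction. Compound 3 is therefore estimated at 5000 nM in this assay, within a range from 1800 nM to 14000 nM. The expected step of a 1.1-fold lower number from compound 2 to compound 3 (0.03 log units; within the scatter) is small and uncertain.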

Compound 3, half-maximal inhibitory concentration: 25700 nM
Estimate against measurement, compound 3: 5.1-fold (0.71 log units) below; measured number above the stated range.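

Putting pyridin-3-yl in place of thiophen-2-yl gives a 4.8-fold higher number from compound 2 to compound 3 (0.68 log units; beyond the scatter) in this assay, so compound 3 is the weaker inhibitor and the two rings are not interchangeable here, even though each has a single hetero atom and a single hydrogen-bond acceptor. This pair therefore gives the first measured sign that the group on this aromatic carbon, next to the ring nitrogen of the shared core, matters for the read-out, although one pair cannot show a wider trend. No measurement is available to explain the difference between the two rings.

The change alters ring size and hetero atom together, so the compounds shown cannot separate the two, and a plain phenyl ring, a furan-2-yl ring or an amine at this position would be needed to test them further. Compound 1 differs from compound 3 only in where the hydroxyl group sits on its phenyl ring, but in this assay compound 1 gives "not determined" (no result reported), so the effect of moving that hydroxyl group cannot be read.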